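Benzyloxy Extension of a Bis-Acylphloroglucinol Cytotoxic Series

The compounds below may be only part of what the source reports. "The series", "measured", "known", "first", "only" and "open" are said of these compounds alone.

Measured compounds:
- compound 1 `CC(C)CC(=O)c1c(O)c(Cc2c(O)c(C(=O)CC(C)C)c(O)c(C(=O)CC(C)C)c2O)c(O)c(C(=O)CC(C)C)c1O`: in an ADME assay on CCRF-CEM cells (Homo sapiens) for cytotoxicity, read by MTT assay, with a stated time of 72 h (on this read-out lower numbers stand for higher toxicity in this test and higher numbers for lower toxicity in this test), compound 1 is reported as "not determined" (no result reported)
- compound 2 `CCC(c1c(O)c(C(C)=O)c(O)c(C(C)=O)c1O)c1c(O)c(C(C)=O)c(O)c(C(C)=O)c1O`: in this assay compound 2 is reported as "not determined" (no result reported)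
- compound 3 `CC(C)CC(=O)c1c(O)c(C(=O)CC(C)C)c(O)c(C(c2ccccc2)c2c(O)c(C(=O)CC(C)C)c(O)c(C(=O)CC(C)C)c2O)c1O`: 3150 nM

Going by the values given here, compound 3 is the only member of the group with a number in this assay; compound 1 stands at "not determined" (no result reported) and compound 2 stands at "not determined" (no result reported), so compound 3 cannot be ranked against anything and simply stands as the sole reference point, with a half-maximal cytotoxic concentration of 3150 nM.

Compound 4 `CC(C)CC(=O)c1c(O)c(C(=O)CC(C)C)c(O)c(C(c2ccc(OCc3ccccc3)cc2)c2c(O)c(C(=O)CC(C)C)c(O)c(C(=O)CC(C)C)c2O)c1O` is not yet measured. It differs from compound 3 by benzyloxy in place of hydrogen on an aromatic carbon. Among the compounds with values here, no step between measured compounds is available to calibrate what such a change does in this assay, so the expectation rests on compound 3 alone. Because compound 3 gives 3150 nM, the estimate for compound 4 is anchored near it, and the step from compound 3 to compound 4 is expected to be small, a 1.3-fold lower number from compound 3 to compound 4 (0.10 log units; within the scatter), not clearly beyond the usual scatter in either direction. Compound 4 is therefore estimated at 2500 nM, within a range of 800 nM to 8000 nM.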

Compound 4, half-maximal cytotoxic concentration: 24000 nM
Compound 4: the middle estimate sits 9.6-fold (0.98 log units) below what was measured; the whole stated range lies below it.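

At this aromatic carbon, para to a large group, the substituent is not a matter of indifference: in this assay benzyloxy in place of hydrogen gives a 7.6-fold higher number from compound 3 to compound 4 (0.88 log units; beyond the scatter) and so means lower toxicity in this test. Going by these compounds alone, this is the only step that can be read here, so it gives the direction of this one change at this one place and establishes no trend. Nothing available explains why the number rises.

Going by these compounds, it remains open whether the rise requires the whole benzyloxy group or would also follow from a smaller methoxy group at the same place. On these data alone, it is equally open how an amine or a carboxylic acid there would move the number, and compound 1 and compound 2 offer no comparison.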